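The source may report more compounds than this note shows. Statements on the series, on what has been measured and on what is new or still open speak of the compounds shown alone.

Measured compounds in an assay on isolated protein for inhibition of malate dehydrogenase, mitochondrial (Sus scrofa), with stated times of 45 min and 30 min; a higher number here means a weaker inhibitor, a lower number a stronger inhibitor:
compound 1 `O=S(=O)(Nc1ccc(-c2nc3ccccc3o2)cc1)c1ccc(F)c(C(F)(F)F)c1` — > 63000 nM
compound 2 `COc1ccc(S(=O)(=O)Nc2ccc(-c3nc4ccccc4o3)cc2)cc1` — > 63000 nM
compound 3 `CCc1ccc(S(=O)(=O)Nc2ccc(-c3nc4ccccc4o3)cc2)cc1` — > 63000 nM

The value of compound 1 is a limit of the assay, not a number. The same holds for compound 2, whose value is likewise only a limit. Compound 3 also returns only a limit. Nothing more is shown than the limit of > 63000 nM in this assay, at which 3 of the 3 values shown sit. Among the compounds with values here, the one step between measured compounds, a step that the two limits leave unreadable from compound 2 to compound 3, cannot therefore be read for size or direction, and no measured step bears on the change now followed.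

Compound 4 `O=S(=O)(Nc1ccc(-c2nc3ccccc3o2)cc1)c1cccc(C(F)(F)F)c1` differs from compound 1 by hydrogen in place of fluoro on an aromatic carbon. With every value shown sitting at the limit, no readable step is available to set an expectation for this assay beyond that of compound 1. Compound 4 is expected to give 100000 nM, within 30000 nM to 400000 nM, most probably again reported only as a limit. The expected step that the limit leaves unreadable from compound 1 to compound 4 is accordingly taken as none beyond the scatter.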

Compound 4, half-maximal inhibitory concentration: > 63000 nM
Compound 4 gave a limit, no number; the forecaster's own chance of this, stated with the estimate: 85%; the middle value does not contradict the limit.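

The step from compound 1 to compound 4 cannot be read, as both values are only limits in this assay: the limit of > 63000 nM in this assay, at which 4 of the 4 values shown sit. The compounds shown leave open which structural change, if any, would give a measurable value in this assay.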